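Furan-3-yl replacing 4-nitrophenyl: expected cytotoxicity of compound 4

The compounds below may be only part of what the source reports. "The series", "measured", "known", "first", "only" and "open" are said of these compounds alone.

Measured compounds:
Compound 1 `COc1cc(CC(O)c2ccc(-c3ccc([N+](=O)[O-])cc3)cc2)c([N+](=O)[O-])cc1OC` gives 21000 nM in an ADME assay on HeLa Rh cells (Homo sapiens) for cytotoxicity, read by microscopy; on this read-out higher numbers stand for lower toxicity in this test and lower numbers for higher toxicity in this test.
Compound 2 `COc1cc(CC(O)c2ccc(-c3cccc(C#N)c3)cc2)c([N+](=O)[O-])cc1OC` gives 5200 nM in this assay.
Compound 3 `COc1cc(CC(O)c2ccc(-c3ccccc3[N+](=O)[O-])cc2)c([N+](=O)[O-])cc1OC` gives 9500 nM in this assay.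

Compound 1 stands highest of the three numbers in this assay. Its nearest neighbour is compound 3, reached by a 2.2-fold lower number from compound 1 to compound 3 (0.34 log units; beyond the scatter), and its furthest is compound 2, reached by a 4.0-fold lower number from compound 1 to compound 2 (0.61 log units; beyond the scatter). Compounds 2 and 3 lie within the scatter of each other, as a 1.8-fold higher number from compound 2 to compound 3 (0.26 log units; within the scatter) shows.

Compound 4 `COc1cc(CC(O)c2ccc(-c3ccoc3)cc2)c([N+](=O)[O-])cc1OC` has not been measured. Its change from compound 1 is furan-3-yl in place of 4-nitrophenyl on an aromatic carbon. The two measured steps that bear on it both leave from the same 4-nitrophenyl group of compound 1, and both gave modest decreases: a 4.0-fold lower number from compound 1 to compound 2 (0.61 log units; beyond the scatter) and a 2.2-fold lower number from compound 1 to compound 3 (0.34 log units; beyond the scatter). The furan-3-yl group is a different kind of replacement, so the analogy is loose, but the pattern among the three suggests a step away from compound 1 that is at most modest and more likely downward than upward. Compound 4 is therefore expected to give about 12000 nM in this assay, within a range of 4000 nM to 36000 nM, which means an expected step of a 1.8-fold lower number from compound 1 to compound 4 (0.24 log units; within the scatter).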

Compound 4, half-maximal cytotoxic concentration: 5300 nM
Estimate against measurement, compound 4: 2.3-fold (0.35 log units) above, within the range that was stated.
By their numbers in this assay, from the lowest: compounds 2, 4 and 3 (each within the scatter of the next); then compound 1.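

In this assay, going by these compounds alone, compound 4 shows that this position, on an aromatic carbon para to a large group, also takes a smaller five-membered ring with an oxygen, not only another six-membered aromatic ring, and that this swap gives a step (a 4.0-fold lower number from compound 1 to compound 4 (0.60 log units; beyond the scatter)) of the same size as the one to compound 2. The furan-3-yl group cannot be told apart from the other two replacements (a 1.8-fold lower number from compound 3 to compound 4 (0.25 log units; within the scatter); a 1.0-fold higher number from compound 2 to compound 4 (0.01 log units; within the scatter)), so compound 1 alone stands apart among the four. Nothing measured bears on why the 4-nitrophenyl group of compound 1 gives the highest number.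

On these data alone, it remains open whether that higher number depends on the nitro group itself. A carboxylic acid or an amine in its place on the phenyl ring, or a plain phenyl group, could show whether it does.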